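Urea-to-amide swap at the aryl end of the series

The source may hold more compounds than are shown below. What is called first, only, known or untested is meant among the compounds shown, and "the series" means these compounds.

Measured compounds:
compound 1 `COc1cc(-c2nn(-c3cccc(NC(=O)Nc4cc(C(F)(F)F)cc(C(F)(F)F)c4)c3)cc2-c2ccncc2)ccc1Cl` gives 932 nM
compound 2 `COc1cc(-c2nn(-c3cccc(NC(=O)Nc4ccc(Cl)c(Cl)c4)c3)cc2-c2ccncc2)ccc1Cl` gives 1470 nM
compound 3 `O=C(Nc1cccc(-n2cc(-c3ccncc3)c(-c3ccc(Cl)c(O)c3)n2)c1)Nc1ccc(Cl)c(Cl)c1` gives 1310 nM

Within the data shown here, in a functional assay on SN12C cells (Homo sapiens) for inhibition, read by sulforhodamine B assay, with a stated time of 48 h (on this read-out lower numbers stand for stronger inhibition of growth and higher numbers for weaker inhibition of growth), compound 2 stands within the scatter of both other compounds: the only single-point step, a 1.1-fold lower number from compound 2 to compound 3 (0.05 log units; within the scatter), is within the scatter, and the values of compound 1 and compound 2 also differ by less than the scatter. Compound 4 `COc1cc(-c2nn(-c3cccc(NC(=O)c4ccc(Cl)c(C(F)(F)F)c4)c3)cc2-c2ccncc2)ccc1Cl` is not yet measured; it differs from compound 2 by 4-chloro-3-(trifluoromethyl)phenyl in place of (3,4-dichlorophenyl)amino on a carbonyl carbon. Among the measured compounds shown here, no measured step touches this part of the molecule, so no direct guide exists; the changes seen so far at the aryl end and at the methoxy group stayed within the scatter. For compound 4 the step is therefore expected to be a 1.2-fold lower number from compound 2 to compound 4 (0.09 log units; within the scatter), with no direction beyond the scatter. Compound 4 is estimated at 1200 nM, between 400 nM and 4000 nM.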

Compound 4, concentration for 50% growth inhibition: 11200 nM
Compound 4: the middle estimate sits 9.3-fold (0.97 log units) below what was measured; measured number above the stated range.
By their numbers in this assay, from the lowest: compounds 1, 3 and 2 (each within the scatter of the next); then compound 4.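

In this assay, among these compounds, the step to the amide, a 7.6-fold higher number from compound 2 to compound 4 (0.88 log units; beyond the scatter), is the first one beyond the scatter, so this position responds where the earlier changes did not. The swap removes the amide-type nitrogen's link to the aryl ring, with one hydrogen-bond donor fewer, and changes the ring substituents at the same time, so the two changes cannot be separated here. No evidence on the cause of this step is available. Whether the urea nitrogen or the trifluoromethyl group accounts for the step remains open. Also open, from the compounds shown here alone, is how an amine or a carboxylic acid on this aryl ring would read.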